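This account rests on a few compounds, and the source may have more. Where it says the series, first, only, none or still open, it means among the compounds named here.

Measured in a functional assay on A549 cells (Homo sapiens) for cytotoxicity, read by MTT assay, with a stated time of 72 h; a higher number here means a weaker inhibitor, a lower number a stronger inhibitor:
- compound 1 `COc1cc2c(Oc3ccc(NC(=O)c4cn(-c5ccccc5)nn4)cc3F)ccnc2cc1OCCCN1CCC(C)CC1` gives 140 nM
- compound 2 `COc1cc2c(Oc3ccc(NC(=O)c4cn(-c5ccccc5F)nn4)cc3F)ccnc2cc1OCCCN1CCC(C)CC1` gives 250 nM
- compound 3 `COc1cc2c(Oc3ccc(NC(=O)c4cn(-c5c(Cl)cccc5Cl)nn4)cc3F)ccnc2cc1OCCCN1CCC(C)CC1` gives 320 nM

Compound 3 holds the highest number of the three. Its nearest neighbour is compound 2, a step that is a 1.3-fold higher number from compound 2 to compound 3 (0.11 log units; within the scatter) and so within the scatter; the gap to compound 1 is larger, a 2.3-fold higher number from compound 1 to compound 3 (0.36 log units; beyond the scatter), and counts as a modest real difference.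

Compound 4 `COc1cc2c(Oc3ccc(NC(=O)c4cn(-c5ccc(F)c(F)c5)nn4)cc3F)ccnc2cc1OCCCN1CCC(C)CC1` is not yet measured. It differs from compound 3 in one place: 3,4-difluorophenyl in place of 2,6-dichlorophenyl on an aromatic nitrogen. Going by the values given here, no measured step matches this exchange. What bears on it is the comparison of ring substitution on the same aromatic nitrogen: a 1.8-fold higher number from compound 1 to compound 2 (0.25 log units; within the scatter), within the scatter, and a 2.3-fold higher number from compound 1 to compound 3 (0.36 log units; beyond the scatter), modest. Both substituted rings gave numbers no lower than the plain phenyl of compound 1, and the two substituted rings sit within the scatter of each other. A difluorinated ring in compound 4 is therefore expected to land near compound 2 and compound 3, with at most a small move in this assay in either direction, not beyond the scatter.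

For compound 4 in this assay the estimate is 250 nM (range 120 nM to 520 nM), which is expected to mean a step of a 1.3-fold lower number from compound 3 to compound 4 (0.11 log units; within the scatter).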

Compound 4, half-maximal inhibitory concentration: 1460 nM
Beside the measured number, compound 4's estimate is 5.8-fold (0.77 log units) below it, outside the stated range (above it).
By their numbers in this assay, from the lowest: compounds 1, 2 and 3 (each within the scatter of the next, the first and the last beyond it); then compound 4.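

In this assay, the aryl group on the aromatic nitrogen of the five-membered ring is not a place of small moves only: the exchange gives a 4.6-fold higher number from compound 3 to compound 4 (0.66 log units; beyond the scatter) and a 5.8-fold higher number from compound 2 to compound 4 (0.77 log units; beyond the scatter), while a 10-fold higher number from compound 1 to compound 4 (1.02 log units; beyond the scatter) is the largest step in the series and the only one printed as large. Halogen on this ring is therefore not uniformly tolerated, since 2-fluorophenyl and 2,6-dichlorophenyl stay within the scatter of each other while 3,4-difluorophenyl stands clearly apart from both, even though 2,6-dichlorophenyl and 3,4-difluorophenyl match in heavy-atom count, hydrogen-bond donors, hydrogen-bond acceptors and net charge. No measurement at hand accounts for the size of these steps.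

Going by these compounds, the halogen and its placement on the ring change together between compound 3 and compound 4, so which of the two carries the step stays open. Also open, on these data alone, is how this position responds to a phenyl ring bearing methoxy, an amine or a carboxylic acid in place of halogen.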